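The source may report more compounds than this note shows. Statements on the series, on what has been measured and on what is new or still open speak of the compounds shown alone.

Among the measured compounds shown here, in a functional assay on A549 cells (Homo sapiens) for antiproliferative activity, read by MTT assay, with a stated time of 48 h (on this read-out higher numbers stand for weaker inhibition and lower numbers for stronger inhibition), three related compounds have numbers so far. Compound 1 `Cc1ccc(-c2cc(NC(=O)/C=C/c3ccc(Cl)cc3)n[nH]2)cc1` gives 1490 nM, compound 2 `O=C(/C=C/c1ccc(Cl)cc1)Nc1cc(-c2ccccc2)[nH]n1` gives 1390 nM, and compound 3 `Cc1ccc(-c2cc(NC(=O)/C=C/c3ccc(C(F)(F)F)cc3)n[nH]2)cc1` gives 1020 nM. Compound 2 lies within the usual scatter of both others, so it holds no distinct rank among them.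

The unmeasured compound 4 `O=C(/C=C/c1ccc([N+](=O)[O-])cc1)Nc1cc(-c2ccccc2)[nH]n1` has nitro in place of chloro on an aromatic carbon, para to a large group, and differs from compound 2 as follows: nitro in place of chloro on an aromatic carbon.

For the measured compounds named here, two measured steps bear on this change. The nearer guide also removes chloro: trifluoromethyl in place of chloro on an aromatic carbon gave a 1.5-fold lower number from compound 1 to compound 3 (0.16 log units; within the scatter). The other, hydrogen in place of methyl on an aromatic carbon, gave a 1.1-fold lower number from compound 1 to compound 2 (0.03 log units; within the scatter). Going by the values given here, both stayed within the scatter, but no measured compound carries nitro, so the guidance is thin.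

No shift beyond the scatter is expected in this assay, and the expected step is a 1.2-fold lower number from compound 2 to compound 4 (0.06 log units; within the scatter). For compound 4 the estimated value is 1200 nM, with an expected range from 500 nM to 2800 nM.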

Compound 4, half-maximal inhibitory concentration: 970 nM
Estimate against measurement, compound 4: 1.2-fold (0.09 log units) above; low and high end bracket the measured number.
By their numbers in this assay, from the lowest: compounds 4, 3, 2 and 1 (each within the scatter of the next).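

In this assay, nitro in place of chloro on this aromatic carbon, para to a large group, gave a 1.4-fold lower number from compound 2 to compound 4 (0.16 log units; within the scatter) and so produced no clear change in the number. Nitro brings 3 heavy atoms and 2 hydrogen-bond acceptors where chloro has 1 heavy atom and 0 acceptors, and like the trifluoromethyl swap, a 1.5-fold lower number from compound 1 to compound 3 (0.16 log units; within the scatter), this second replacement of chloro at the position also stays without a shift beyond the scatter. No measurement shown here offers an explanation for this result.

From the compounds shown here alone, whether an amine, a carboxylic acid or a longer chain at this position would move the number beyond the scatter remains open, as does the effect of plain hydrogen there. Nitro also appears only on the core of compound 2, so its effect alongside the methyl of compound 1 is unknown.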